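Three Triazine Rings on One Furanone Core

The source may report more compounds than this note shows. Statements on the series, on what has been measured and on what is new or still open speak of the compounds shown alone.

Compound 1 `O=C1O/C(=C\Cn2ncc(=O)[nH]c2=O)C(OCc2ccccc2)=C1OCc1ccccc1`: 45000 nM
Compound 2 `Nc1ncn(C/C=C2\OC(=O)C(OCc3ccccc3)=C2OCc2ccccc2)c(=O)n1`: 5910 nM
Compound 3 `O=C1O/C(=C\Cn2c(=O)[nH]c(=O)[nH]c2=O)C(OCc2ccccc2)=C1OCc1ccccc1`: not yet measured

Among the measured compounds shown here, in a functional assay on HeLa cells (Homo sapiens) for inhibition, read by MTT assay, with a stated time of 72 h (on this read-out lower numbers stand for stronger inhibition and higher numbers for weaker inhibition), compound 2 holds the lowest of the two measured numbers; its only neighbour is compound 1, separated from it by the step of a 7.6-fold lower number from compound 1 to compound 2 (0.88 log units; beyond the scatter). Compound 3 keeps the shared core and changes only the ring on the saturated chain carbon bound to a double-bonded chain carbon: a group of 9 heavy atoms (3 carbon, 3 nitrogen, 3 oxygen; one six-membered aromatic ring with 3 hetero atoms) in place of a group of 8 heavy atoms (3 carbon, 4 nitrogen, 1 oxygen; one six-membered aromatic ring with 3 hetero atoms), on a saturated chain carbon bound to a double-bonded chain carbon. For the measured compounds named here, the single measured step that bears on this is a 7.6-fold lower number from compound 1 to compound 2 (0.88 log units; beyond the scatter), in which a ring with 3 nitrogen and 2 oxygen atoms gave way to the ring with 4 nitrogen and 1 oxygen. Compound 3 moves the other way, from that nitrogen-rich ring to one with 3 oxygen atoms, 3 double bonds outside aromatic rings and 2 hydrogen-bond donors, closer in make-up to the ring of compound 1. A rise beyond the scatter is therefore expected for compound 3, of about a 4.2-fold higher number from compound 2 to compound 3 (0.63 log units; beyond the scatter). Compound 3 is estimated at 25000 nM, within a range from 8000 nM to 80000 nM.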

Compound 3, half-maximal inhibitory concentration: > 100000 nM
Compound 3 ended at the assay's limit; the forecaster's own chance of this, stated with the estimate: 15%; at least 4.0-fold (0.60 log units) between middle value and limit.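

In this assay compound 3 gives a limit and not a number: the limit of > 100000 nM in this assay, at which 1 of the 3 values shown sits.

Among the compounds shown here, on the saturated chain carbon bound to a double-bonded chain carbon, a change of ring alone now spans more than the one earlier step could show, with an at least 16-fold higher number from compound 2 to compound 3 (1.22 log units; beyond the scatter) when the group of 9 heavy atoms (3 carbon, 3 nitrogen, 3 oxygen) replaces the group of 8 heavy atoms (3 carbon, 4 nitrogen, 1 oxygen). Even against the ring of compound 1, which also carries more oxygen than that of compound 2, the new ring goes further, with an at least 2.2-fold higher number from compound 1 to compound 3 (0.34 log units; beyond the scatter), so that the three compounds line up from the lowest number to the highest as compound 2, compound 1, compound 3, in step with the oxygen count of the ring, and none of the three goes against this order.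

From the compounds shown here alone, how far past its limit compound 3 lies stays unknown, and three rings are too few to say whether the order is more than a coincidence. Also open, going by these compounds, is how a ring carrying a methyl group or a thiocarbonyl would fall in this order, and whether the order survives a longer chain in this place.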